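A few compounds are considered here, and "the series" means these few. Any claim that something is new, unique, unknown or untested is made for them only; others in the source may bear on it.

In an ADME assay on microsomes from liver (Mus musculus) for metabolic stability, using NADPH, with a stated time of 10 min (on this read-out higher numbers stand for a more stable compound and lower numbers for a less stable compound), compound 1 (`CN(C[C@H]1Cc2ncccc2CN1)[C@H]1CCCc2cccnc21`) gives 53%, compound 2 (`NC/C=C/CN(C[C@H]1Cc2ncccc2CN1)[C@H]1CCCc2cccnc21`) gives 37% and compound 3 (`NC(=O)NC/C=C/CN(C[C@H]1Cc2ncccc2CN1)[C@H]1CCCc2cccnc21`) gives 19%. Compound 3 therefore stands lowest of the three, clearly under both of the others. The measured steps show a number 16 percentage points lower from compound 1 to compound 2 (beyond the scatter) and then, with carbamoyl in place of hydrogen on an amine nitrogen, a number 18 percentage points lower from compound 2 to compound 3 (beyond the scatter). Taken whole, the change amounts to a number 34 percentage points lower from compound 1 to compound 3 (beyond the scatter).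

Compound 4 (`CN(C)CCCCN(C[C@H]1Cc2ncccc2CN1)[C@H]1CCCc2cccnc21`) has not yet been measured. Its difference from compound 3 is a group of 6 heavy atoms (5 carbon, 1 nitrogen; no ring) in place of a group of 7 heavy atoms (4 carbon, 2 nitrogen, 1 oxygen; no ring), on a saturated chain carbon bound to an amine nitrogen, and the entering group is 3-(dimethylamino)propyl, on a saturated chain carbon bound to an amine nitrogen. For the measured compounds named here, no measured step exchanges one such chain directly for another. The closest guide is a number 18 percentage points lower from compound 2 to compound 3 (beyond the scatter), since compound 4 carries no carbamoyl, and part of that loss may be expected to return. Compound 4 still keeps a chain that compound 1 lacks, so a return to the 53% of compound 1 is not the expectation. A modest rise in this assay is therefore expected, and the expected change is a number 13 percentage points higher from compound 3 to compound 4 (beyond the scatter). For compound 4 the estimated value is 32%, with an expected range from 15% to 50%.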

Compound 4, percent of the compound remaining: 55%
Estimate against measurement, compound 4: 23 percentage points below; the measured number lies above the stated range.
By their numbers in this assay, from the lowest: compound 3; then compound 2; then compounds 1 and 4 (each within the scatter of the next).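

In this assay, the two chains seen earlier on the saturated chain carbon bound to an amine nitrogen both came with a loss, but 3-(dimethylamino)propyl in place of hydrogen gives a number 2 percentage points higher from compound 1 to compound 4 (within the scatter), so a chain at this place does not by itself lower the number. The identity of the chain therefore matters: 3-(dimethylamino)propyl in place of 3-aminoprop-1-en-1-yl gives a number 18 percentage points higher from compound 2 to compound 4 (beyond the scatter), and in place of the group of 7 heavy atoms that compound 3 carries, it gives a number 36 percentage points higher from compound 3 to compound 4 (beyond the scatter), which recovers the whole loss that the earlier chains had shown. Nothing available here offers an explanation for these differences.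

Compound 4 differs from compound 2 both in the double bond of the chain and in the two methyl groups on its terminal nitrogen, and the step alone does not separate these two changes. Also open, as far as these compounds go, is where a saturated chain ending in a primary amine, a chain ending in a morpholine, or a chain ending in a carboxylic acid would stand in this assay.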